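The compounds below may be only part of what the source reports. "The series", "measured", "known", "first", "only" and "open" are said of these compounds alone.

Compound 1 `COc1ccc(C(=O)Nc2ccc3c(c2)/C(=C/Nc2cccc(N4CCN(C)CC4)c2)C(=O)N3)cc1`: 3170 nM
Compound 2 `CN1CCN(c2cccc(N/C=C3\C(=O)Nc4ccc(NC(=O)c5cccc(F)c5)cc43)c2)CC1`: 8500 nM

Both values come from a functional assay on BGC-823 cells (Homo sapiens) for inhibition, read by sulforhodamine B assay, with a stated time of 3 days; a lower number here means a stronger inhibitor, a higher number a weaker inhibitor. For the measured compounds named here, of these two numbers, compound 2 has the higher, at 8500 nM, which makes it the weaker inhibitor, and its only neighbour is compound 1 at 3170 nM. The next compound, compound 3 `CN1CCN(c2cccc(N/C=C3\C(=O)Nc4ccc(NC(=O)c5c(F)cccc5F)cc43)c2)CC1`, has not yet been measured. It carries 2,6-difluorophenyl in place of 3-fluorophenyl on a carbonyl carbon.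

Going by the values given here, only one measured step bears on this change: a 2.7-fold higher number from compound 1 to compound 2 (0.43 log units; beyond the scatter). That step, with 3-fluorophenyl in place of 4-methoxyphenyl on the same carbonyl carbon, was modest but beyond the scatter. It shows that a change at this place can move the number, yet it involves no 2,6-difluorophenyl group and so gives no firm direction. A step of similar size at most is therefore expected in this assay, and the most likely outcome is a small one with no clear direction. The estimated change is a 1.3-fold lower number from compound 2 to compound 3 (0.12 log units; within the scatter). For compound 3 the expected value is 6500 nM, with an estimated range of 2500 nM to 16000 nM.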

Compound 3, half-maximal inhibitory concentration: 2670 nM
Beside the measured number, compound 3's estimate is 2.4-fold (0.39 log units) above it; the measured number falls inside the stated range.
By their numbers in this assay, from the lowest: compounds 3 and 1 (each within the scatter of the next); then compound 2.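

In this assay, for the compounds shown here, the change to 2,6-difluorophenyl on the carbonyl carbon gives a 3.2-fold lower number from compound 2 to compound 3 (0.50 log units; beyond the scatter), showing that a change at this place can lower the number as well as raise it, which the single earlier step could not show. Fluorine on this ring does not by itself set the number: the 3-fluorophenyl and 2,6-difluorophenyl groups differ beyond the scatter, whereas replacing 4-methoxyphenyl with 2,6-difluorophenyl gives a 1.2-fold lower number from compound 1 to compound 3 (0.07 log units; within the scatter), leaving those two groups indistinguishable here. No measurement at hand accounts for these differences.

The compounds shown leave open whether the number follows the count of fluorine atoms or their placement on the ring, a question that an unsubstituted phenyl or a chlorophenyl group on the same carbonyl carbon would help to frame. They also leave open whether the number can fall clearly below the level shared by compound 1 and compound 3, for instance with a ring carrying an amine or a carboxylic acid, and whether the same differences hold in other cells.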